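Swapping the amino group of compound 1 for a second methylselanyl

The compounds below may be only part of what the source reports. "The series", "measured", "known", "first", "only" and "open" are said of these compounds alone.

Compound 1 `C[Se]c1nc(N)c2ccccc2n1` is the weaker of the two measured compounds: in a functional assay on CCRF-CEM cells (Homo sapiens) for cytotoxicity, read by MTT assay, with a stated time of 72 h (a higher number here means a weaker inhibitor of growth, a lower number a stronger inhibitor of growth), compound 1 gives 65100 nM, while compound 2 `Nc1nc([SeH])nc2ccccc12` gives 25700 nM. For the measured compounds named here, the only measured step, a 2.5-fold lower number from compound 1 to compound 2 (0.40 log units; beyond the scatter), shows that changing the group on the selenium can shift the number by a modest but real amount. Compound 3 `C[Se]c1nc([Se]C)c2ccccc2n1` differs from compound 1 in another place: a group of 2 heavy atoms (1 carbon, 1 selenium; no ring) in place of one nitrogen atom, on an aromatic carbon. Going by the values given here, no measured step touches the amino group, so the step of a 2.5-fold lower number from compound 1 to compound 2 (0.40 log units; beyond the scatter) tells only that this core tolerates small changes without large swings, and gives no direction for the present change. On that basis the expected step of a 1.1-fold lower number from compound 1 to compound 3 (0.04 log units; within the scatter) is small and of uncertain direction, likely within the scatter. Compound 3 is therefore estimated at 60000 nM in this assay, with a range from 15000 nM to 200000 nM.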

Compound 3, concentration for 50% growth inhibition: 31200 nM
Beside the measured number, compound 3's estimate is 1.9-fold (0.28 log units) above it; the range from low to high includes it.
By their numbers in this assay, from the lowest: compounds 2 and 3 (each within the scatter of the next); then compound 1.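

Replacing the amino group, on the aromatic carbon of the shared core, with a second methylselanyl group gives a 2.1-fold lower number from compound 1 to compound 3 (0.32 log units; beyond the scatter) in this assay, so the amino group is not required for growth inhibition in these cells. The entering group has none of the hydrogen-bond donors or acceptors counted on the amino group, yet the number does not rise, and this position can take a larger group without a loss. No measurement at hand gives a reason for this modest step.

Going by these compounds, it remains open whether the gain depends on selenium itself, which a methylthio group in the same place could test. The compounds shown also leave open how a hydroxyl group, a methylamino group or a longer chain such as ethylselanyl would behave here.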